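The compounds below may be only part of what the source reports. "The series", "measured", "known", "first", "only" and "open" are said of these compounds alone.

Working notes on the series. In an ADME assay on HepG2 cells (Homo sapiens) for cytotoxicity, read by MTT assay, with a stated time of 72 h (a lower number here means a stronger inhibitor, a higher number a weaker inhibitor), compound 1 `Cc1ccc(S(=O)(=O)Cc2nc(Nc3ccccc3)c3cc([N+](=O)[O-])ccc3n2)cc1` gives > 25000 nM. That entry is a limit of the assay and not a number. Compound 2 `Cc1ccc(S(=O)(=O)Cc2nc(Nc3cccc(Br)c3)c3cc([N+](=O)[O-])ccc3n2)cc1` has no number at all: its entry reads "nd(insoluble)" (no result reported), so no result was reported for it. Among the compounds with values here, the only reference point on this scale is therefore (the limit of > 25000 nM in this assay, at which 1 of the 2 values shown sits), and no measured step gives a size to work from.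

Compound 3 `Cc1ccc(S(=O)(=O)Cc2nc(Nc3cccc(Cl)c3)c3cc([N+](=O)[O-])ccc3n2)cc1` differs from compound 2 in one place, with chloro in place of bromo on an aromatic carbon, meta to a large group, so that 3-bromophenyl becomes 3-chlorophenyl: chloro in place of bromo on an aromatic carbon. In this assay this exchange is expected to bring no step beyond the usual scatter, in either direction, although compound 2 offers no number to test that against. The expectation leans on compound 1 at > 25000 nM, which is again only a limit. Compound 3 may well be reported as a limit too. Should a number be returned, the estimate for compound 3 is 25000 nM, with an expected range of 10000 nM to 50000 nM.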

Compound 3, half-maximal inhibitory concentration: > 100000 nM
Compound 3: only a limit was reported; the forecaster's own chance of this, stated with the estimate: 65%; middle value at least 4.0-fold (0.60 log units) from the limit.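

In this assay compound 3 gives > 100000 nM, which is a limit and not a number. Compound 1 gives > 25000 nM, also a limit. Within the data shown here, with compound 2 offering no number, no step to compound 3 can be read. From the compounds shown here alone, what remains open is how chloro compares with hydrogen or bromo on this scale.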